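This account rests on a few compounds, and the source may have more. Where it says the series, first, only, none or still open, it means among the compounds named here.

Three compounds have been measured in a functional assay on MCF7 cells (Homo sapiens) for cytotoxicity, read by MTT assay, with a stated time of 48 h; on this read-out lower numbers stand for stronger inhibition and higher numbers for weaker inhibition:

Compound 1, `Fc1cccc(-c2nc(Nc3ccccc3)c3cc(F)ccc3n2)c1`, gives 49700 nM.
Compound 2, `COc1ccc(Nc2nc(-c3cccc(F)c3)nc3ccc(F)cc23)cc1`, gives 48400 nM.
Compound 3, `Fc1ccc(Nc2nc(-c3cccc(F)c3)nc3ccc(F)cc23)cc1`, reaches only the limit of > 50000 nM, which is a limit of the assay and not a number.

Compound 3 therefore stands at the top of the numbers shown, with no value of its own, and the step of a number no lower from compound 1 to compound 3 (the limit leaves the size open) and the step of an at least 1.0-fold higher number from compound 2 to compound 3 (0.01 log units; that floor lies within the scatter) are open in size for the same reason (the limit of > 50000 nM in this assay, at which 1 of the 3 values shown sits). Compound 4, `Fc1cccc(-c2nc(Nc3ccccc3F)c3cc(F)ccc3n2)c1`, differs from compound 3 in one place: 2-fluorophenyl in place of 4-fluorophenyl on a nitrogen on an aromatic ring. Among the compounds with values here, no measured step changes the position of a substituent on this phenyl; the steps seen, a 1.0-fold lower number from compound 1 to compound 2 (0.01 log units; within the scatter) and the two steps into compound 3, all stay within the scatter or end at the limit. On this basis compound 4 is expected to show a number no higher from compound 3 to compound 4 (the limit leaves the size open). Compound 4 is estimated at 50000 nM, within 25000 nM to 100000 nM, and it may well end at the limit again.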

Compound 4, half-maximal inhibitory concentration: > 50000 nM
Compound 4: no number, only a limit (the forecaster's own chance of this, stated with the estimate: 50%); the middle value sits exactly at the limit.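

In this assay compound 4 gives > 50000 nM, which is a limit of the assay and not a number, the same kind of result that compound 3 gave. The step from compound 3 to compound 4 cannot be read. Of the other two steps, one is a number no lower from compound 1 to compound 4 (the limit leaves the size open), and the only one with a floor is an at least 1.0-fold higher number from compound 2 to compound 4 (0.01 log units; that floor lies within the scatter). With the 2-fluorophenyl and the 4-fluorophenyl on this nitrogen both ending at a limit, the change between them yields no readable number, and the series now gathers at that limit: the limit of > 50000 nM in this assay, at which 2 of the 4 values shown sit.

Going by these compounds, how far compound 3 and compound 4 lie beyond the limit, and whether they differ at all, stays open. On these data alone, it is also open whether an amine or a carboxylic acid on this phenyl would give a readable number against the shared core.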